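The source may report more compounds than this note shows. Statements on the series, on what has been measured and on what is new or still open speak of the compounds shown alone.

Compound 1 `CC(C)N1CCN(Cc2csc(N)c2C(=O)c2ccc(Cl)cc2)CC1`, compound 2 `Nc1scc(CN2CCN(c3ccncc3)CC2)c1C(=O)c1ccc(Cl)cc1` and compound 3 `Nc1scc(CN2CCN(c3cccc(F)c3)CC2)c1C(=O)c1cccc(C(F)(F)F)c1` have been tested in a functional assay on CHO cells with adenosine receptor A1 (Homo sapiens) as the target, read by cAMP accumulation and immunoassay, with a stated time of 6 min, tested at 0.01 uM; on this read-out lower numbers stand for a stronger effect and higher numbers for a weaker effect at the one concentration tested. Compound 1 gives -1%, compound 2 gives -4% and compound 3 gives -11%. Compound 3 has the lowest of the three numbers, yet its gaps to compound 2 and to compound 1 both lie within the scatter. Among the compounds with values here, the single measured step, a number 3 percentage points lower from compound 1 to compound 2 (within the scatter), concerns a different place on the shared core and does not bear on the change at hand. Compound 4 `Nc1scc(CN2CCN(c3cccc(F)c3)CC2)c1C(=O)c1ccc(Cl)cc1` differs from compound 3 by 4-chlorophenyl in place of 3-(trifluoromethyl)phenyl on a carbonyl carbon. Within the data shown here, no measured pair isolates this change; compounds 1 and 2 carry the entering group and show numbers close to that of compound 3. A step of a number 6 percentage points higher from compound 3 to compound 4 (within the scatter) is therefore expected, nothing beyond the scatter. Compound 4 is estimated at -5%, within -15% to 5%.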

Compound 4, a percentage reported as activity, at one concentration (the size of the read-out at that concentration, not a potency): -18%
The estimate for compound 4 lay 13 percentage points above the measured number, and the stated range ends above it.
By their numbers in this assay, from the lowest: compounds 4, 3, 2 and 1 (each within the scatter of the next, the first and the last beyond it).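

In this assay, the change on the carbonyl carbon stays within the scatter (a number 7 percentage points lower from compound 3 to compound 4 (within the scatter)), so 4-chlorophenyl and 3-(trifluoromethyl)phenyl cannot be told apart here. Within the data shown here, with 4-chlorophenyl held in place, the amine nitrogen in a ring gives the first steps beyond the scatter, both modest: 3-fluorophenyl replacing pyridin-4-yl gives (a number 14 percentage points lower from compound 2 to compound 4 (beyond the scatter)), and 3-fluorophenyl replacing isopropyl gives (a number 17 percentage points lower from compound 1 to compound 4 (beyond the scatter)). No measurement offered here explains these steps. Still open, from the compounds shown here alone, is what a longer chain on that nitrogen would give, or a carboxylic acid on the aromatic ring at the carbonyl carbon.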